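The compounds below may be only part of what the source reports. "The series", "measured", "known", "first", "only" and "open" are said of these compounds alone.

Three compounds have been measured in a functional assay on the whole organism for inhibition, with Rattus norvegicus as the target, read by cytopathic effect and paw edema, at a dose of 100 mg/kg by the oral route; on this read-out lower numbers stand for less inhibition and higher numbers for more inhibition at the one dose given (going by the name of the read-out):

Compound 1, `CCCCNC(=O)c1c(O)c2cccnc2n(-c2ccccc2)c1=O`, gives 20.4% in this assay.
Compound 2, `O=C(NN1CCOCC1)c1c(O)c2cccnc2n(-c2ccccc2)c1=O`, gives -26.2% in this assay.
Compound 3, `Cc1ccc(NC(=O)c2c(O)c3cccnc3n(-c3ccccc3)c2=O)cc1`, gives 2.2% in this assay.

Compound 1 stands highest of the three. Its nearest neighbour is compound 3, reached by the step of a number 18.2 percentage points lower from compound 1 to compound 3 (beyond the scatter), and its furthest is compound 2, reached by the step of a number 46.6 percentage points lower from compound 1 to compound 2 (beyond the scatter). Between those two, the step of a number 28.4 percentage points higher from compound 2 to compound 3 (beyond the scatter) shows that 4-methylphenyl recovers part of what morpholin-4-yl lost.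

The account now turns to compound 4, `O=C(Nc1ccc(Cl)cc1)c1c(O)c2cccnc2n(-c2ccccc2)c1=O`, which has not yet been measured. Compound 4 differs from compound 1 in one place: 4-chlorophenyl in place of butyl on an amide-type nitrogen.

For the measured compounds named here, the step that bears most directly on this change is the one from compound 1 to compound 3, where another aryl group took the place of butyl on the same amide-type nitrogen and the read-out fell by a modest amount, beyond the scatter. The larger drop to compound 2 came with a ring of a different kind and is less closely related. A drop of about the same modest size as that seen for compound 3 is therefore expected for compound 4, in the downward direction.

Compound 4 is expected to give 4%, with a range from -20% to 26%. That expectation amounts to a step of a number 16.4 percentage points lower from compound 1 to compound 4 (beyond the scatter).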

Compound 4, a percentage reported as inhibition, in the whole organism at one dose (the size of the read-out at that dose, not a potency): 2.5%
Beside the measured number, compound 4's estimate is 1.5 percentage points above it; measured number inside the range.
By their numbers in this assay, from the lowest: compound 2; then compounds 3 and 4 (each within the scatter of the next); then compound 1.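

In this assay, a second aryl group on the amide-type nitrogen again falls short of butyl, with a number 17.9 percentage points lower from compound 1 to compound 4 (beyond the scatter), so the drop seen with 4-methylphenyl is not confined to that one group and holds for both aryl groups shown. Chloro in place of methyl on the aromatic carbon gives a number 0.3 percentage points higher from compound 3 to compound 4 (within the scatter), so this exchange leaves the read-out unchanged within the scatter and compounds 3 and 4 cannot be told apart at the one dose given. Against morpholin-4-yl, 4-chlorophenyl gives a number 28.7 percentage points higher from compound 2 to compound 4 (beyond the scatter), which matches what the earlier compounds showed for 4-methylphenyl: both aryl groups stand clear of morpholin-4-yl on this nitrogen, while neither reaches butyl.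

Nothing in the data shown accounts for these differences. It remains open whether a chain longer or shorter than butyl, a benzyl group, or a methoxy group or carboxylic acid on the aromatic ring would move the read-out, and how any of these compounds would behave at another dose.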